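The source may hold more compounds than are shown below. What is called first, only, known or untested is meant among the compounds shown, and "the series" means these compounds.

Series notes. Compound 1 `Nc1ccccc1/C=C/c1ccccc1O`, compound 2 `COc1ccccc1/C=C/c1ccccc1O` and compound 3 `COc1ccc(/C=C/c2ccccc2O)cc1` have each been run in an ADME assay on HEK293 cells (Homo sapiens) for inhibition, read by MTT assay, with a stated time of 2 days; a higher number here means a weaker inhibitor, a lower number a stronger inhibitor. In this assay compound 2 gives 15 ug/mL, compound 1 gives 27 ug/mL and compound 3 gives 21 ug/mL. Compound 1 differs from compound 2 by amino in place of methoxy on an aromatic carbon, and this change made the step of a 1.8-fold higher number from compound 2 to compound 1 (0.26 log units; within the scatter). Compound 3 and compound 2 are built from the same atoms joined differently; the difference between the two cores is not broken down here. The values of compound 3 and compound 2 lie within the scatter of each other, as do those of compound 3 and compound 1, so no order among the three is claimed.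

Compound 4 `Nc1ccc(/C=C/c2ccccc2O)cc1` has not yet been measured. It differs from compound 3 by amino in place of methoxy on an aromatic carbon. Going by the values given here, this is the same kind of change as the one from compound 2 to compound 1, not the same: in compound 1 the amino sits ortho to a group of 9 heavy atoms, in compound 4 it sits para to a group of 9 heavy atoms. Among the compounds with values here, only one measured step of this kind exists, so the expectation rests on it alone. The expected step in this assay is a 1.5-fold higher number from compound 3 to compound 4 (0.18 log units; within the scatter), kept close to the earlier step because a 1.8-fold higher number from compound 2 to compound 1 (0.26 log units; within the scatter) stayed within the scatter. Compound 4 is therefore expected to give about 32 ug/mL in this assay, with a likely range from 15 ug/mL to 65 ug/mL.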

Compound 4, half-maximal inhibitory concentration: 21.4 ug/mL
Compound 4: middle estimate off by 1.5-fold (0.17 log units), on the high side; the measured number falls inside the stated range.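

In this assay, amino in place of methoxy on an aromatic carbon, para to a group of 9 heavy atoms, gives a 1.0-fold higher number from compound 3 to compound 4 (0.01 log units; within the scatter). Set beside the earlier step, the change reads the same on the two cores as far as this assay can tell: the same change on two cores in this assay, a 1.8-fold higher number (0.26 log units; within the scatter) from compound 2 to compound 1 and a 1.0-fold higher number (0.01 log units; within the scatter) from compound 3 to compound 4, 1.8-fold (0.25 log units) apart, within the scatter of two such steps. Going by these compounds alone, this shows only that neither step, nor the gap between them, rises out of the scatter, so the change has no resolved effect on either core here; it does not show that the two steps are equal, that the place of the amino group is without consequence, or that the result would carry to any core other than those of compound 2 and compound 3.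

The compounds shown leave open how other groups at these places would read, such as a hydroxyl, a dimethylamino group, a carboxylic acid or a longer chain such as ethoxy in place of methoxy. Within the data shown here, with only two pairs for this one change, both read in a single assay, it also remains open whether any replacement at these places moves the number beyond the scatter.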